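Working notes: oxime acid series, step from compound 3 to 4

This account rests on a few compounds, and the source may have more. Where it says the series, first, only, none or still open, it means among the compounds named here.

Three members of the series carry numbers in a functional assay for inhibition of Polyunsaturated fatty acid 5-lipoxygenase (Homo sapiens) (on this read-out higher numbers stand for weaker inhibition and lower numbers for stronger inhibition), so far. Compound 1 `C/C(=N\OC(CC1CCCCC1)c1ccc(OCc2ccc3ccccc3n2)cc1)C(=O)O` gives 29 nM in this assay, and compound 2 `C/C(=N\OC(Cc1ccccc1)c1ccc(OCc2ccc3ccccc3n2)cc1)C(=O)O` gives 30 nM there. Within the data shown here, the one step among them, a 1.0-fold higher number from compound 1 to compound 2 (0.01 log units; within the scatter), shows that the phenyl-for-cyclohexyl exchange on the chain leaves the number where it was. Compound 3 `CC(C)(CC(O/N=C/C(=O)O)c1ccc(OCc2ccc3ccccc3n2)cc1)c1ccccc1` gives 10 nM and stands lowest of the three, beyond the scatter against both compound 1 and compound 2.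

Compound 4 `C/C(=N\OC(CC(C)(C)c1ccccc1)c1ccc(OCc2ccc3ccccc3n2)cc1)C(=O)O` has not been measured yet. Among the measured compounds shown here, it differs from compound 3 by a group of 6 heavy atoms (3 carbon, 1 nitrogen, 2 oxygen; no ring) in place of a group of 5 heavy atoms (2 carbon, 1 nitrogen, 2 oxygen; no ring), on an oxygen on a saturated carbon; the larger group that enters is the one compound 1 and compound 2 carry, while the chain is that of compound 3. For the measured compounds named here, no measured step isolates this exchange, and the step from compound 1 to compound 2 concerns a different part of the molecule. Compound 3 is therefore the only anchor, with compounds 1 and 2 marking where the entering group sits in other company. For compound 4 a number between those anchors is expected, the step from compound 3 being a 1.8-fold higher number from compound 3 to compound 4 (0.26 log units; within the scatter) as a working guess. Compound 4 is expected at about 18 nM, within a range of 7 nM to 45 nM in this assay.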

Compound 4, half-maximal inhibitory concentration: 22 nM
Compound 4: the middle estimate sits 1.2-fold (0.09 log units) below what was measured, and the stated range covers the measured number.
By their numbers in this assay, from the lowest: compound 3; then compounds 4, 1 and 2 (each within the scatter of the next).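

Exchange at this place, on an oxygen on a saturated carbon, now has a reading: in this assay the group of 6 heavy atoms in place of the group of 5 heavy atoms gives a 2.2-fold higher number from compound 3 to compound 4 (0.34 log units; beyond the scatter) and so registers as a modest step beyond the scatter, with one more carbon entering and the counts of hydrogen-bond donors and acceptors unchanged. With that larger group held fixed, the chain adds two readings, a 1.4-fold lower number from compound 2 to compound 4 (0.13 log units; within the scatter) and a 1.3-fold lower number from compound 1 to compound 4 (0.12 log units; within the scatter), both within the scatter, so 1-methyl-1-phenylethyl does not separate from phenyl or cyclohexyl in this assay and the earlier flat chain step now extends to a third chain. Nothing at hand gives a reason for the step at the oxygen-borne group.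

Going by these compounds, the smaller group appears here only with the 1-methyl-1-phenylethyl chain, so whether the same step recurs with the phenyl or cyclohexyl chain stays open. Also open, on these data alone, is how this place answers to groups beyond these two, such as an amide or a longer chain in place of the group of 5 heavy atoms.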